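This account rests on a few compounds, and the source may have more. Where it says the series, first, only, none or still open, it means among the compounds named here.

Measured so far:
- compound 1 `CCCSc1nc(N/N=C(\C)c2ccccc2O)c2nnn(Cc3ccc(Cl)cc3)c2n1`: 42600 nM
- compound 2 `CCCSc1nc(N/N=C/c2cccnc2)c2nnn(Cc3ccccc3)c2n1`: 58700 nM

Both were tested in a functional assay on MCF7 cells (Homo sapiens) for antiproliferative activity, read by MTT assay, with a stated time of 72 h; on this read-out higher numbers stand for weaker inhibition and lower numbers for stronger inhibition. Compound 1 gives 42600 nM and compound 2 gives 58700 nM; the two numbers lie within the usual scatter of each other, so neither compound can be said to inhibit the cells more strongly than the other. Both numbers are high, meaning only weak inhibition.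

Compound 3 `CCCSc1nc(N/N=C(\C)c2ccccc2O)c2nnn(Cc3ccccc3Cl)c2n1` has not yet been tested in this assay. It differs from compound 1 in a single place: 2-chlorophenyl in place of 4-chlorophenyl on a saturated chain carbon bound to an aromatic nitrogen. The chlorine atom simply moves to another position on the same ring; no atom is added or taken away.

Within the data shown here, with only two measured compounds and no measured step of this kind, there is no basis for expecting a move beyond the scatter. The step from compound 1 to compound 3 is therefore expected to be a 1.1-fold higher number from compound 1 to compound 3 (0.02 log units; within the scatter). For compound 3 the estimated value in this assay is 45000 nM, with a range from 15000 nM to 130000 nM.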

Compound 3, half-maximal inhibitory concentration: > 64000 nM
Compound 3 gave a limit, no number; the forecaster's own chance of this, stated with the estimate: 15%; middle value at least 1.4-fold (0.15 log units) from the limit.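

In this assay, moving the chlorine from 4-chlorophenyl to 2-chlorophenyl gives the first view of how this ring, on a saturated chain carbon bound to an aromatic nitrogen, responds to a change, and compound 3 returns a limit of the assay, not a number: the limit of > 64000 nM in this assay, at which 1 of the 3 values shown sits.

The step reads an at least 1.5-fold higher number from compound 1 to compound 3 (0.17 log units; that floor lies within the scatter), so this shift of the chlorine, with the same atoms joined differently, brings no stronger inhibition. Only a floor for the step is known, and the true size could be small or much larger.

Whether the position of the chlorine truly matters therefore stays open, as does the reason for any effect. On these data alone, it is also open how a fluorine, a methoxy group or an amine on the same ring would behave in place of the chlorine.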